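The source may hold more compounds than are shown below. What is called first, only, known or untested is meant among the compounds shown, and "the series" means these compounds.

Among the measured compounds shown here, in a functional assay on HL-60 cells (Homo sapiens), with a stated time of 48 h (a lower number here means that less compound is needed, a higher number that more compound is needed for the effect), compound 1 (`COc1ccc(/C=C(\C)c2ccc3c(c2)C(C)(C)CCC3(C)C)cc1N`) gives 40000 nM, the only actual number so far. Compound 2 (`COc1ccc(/C=C/c2ccc3c(c2)C(C)(C)CCC3(C)C)cc1`) is reported only as a limit of the assay, > 100000 nM. Compound 3 (`COc1ccc(/C=C(/C)c2ccc3c(c2)C(C)(C)CCC3(C)C)cc1N`) has the same atoms and bonds as compound 1 and differs only in configuration as drawn: the two compounds have the same atoms and bonds and differ only in configuration as drawn: 1 of 1 stereo elements differ; a double bond is drawn E in compound 1 and Z in compound 3. For the measured compounds named here, no measured pair shows what such a change does. In this assay, a modest move toward a higher number is expected, meaning that more compound would be needed. The expected step is a 1.5-fold higher number from compound 1 to compound 3 (0.18 log units; within the scatter). Compound 3 is estimated at 60000 nM, within a range of 20000 nM to 150000 nM.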

Compound 3, concentration for half-maximal activity: 90000 nM
Compound 3: middle estimate off by 1.5-fold (0.18 log units), on the low side; the range from low to high includes it.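

In this assay, the configuration of the double bond alone changes the result, with a 2.3-fold higher number from compound 1 to compound 3 (0.35 log units; beyond the scatter). This is the first pair shown that isolates a single change, and the E form drawn in compound 1 needs less compound than the Z form. The step can be traced to that configuration alone, and to no other change: the fact that compounds 1 and 3 differ only in the configuration as drawn

Compound 2 is reported only as a limit of the assay, > 100000 nM. As far as these compounds go, whether the same order of E and Z holds with a carboxylic acid or a hydroxyl group in place of the amine stays open.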